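Cyano to ethoxycarbonyl on the shared core

A few compounds are considered here, and "the series" means these few. Any claim that something is new, unique, unknown or untested is made for them only; others in the source may bear on it.

Measured in a physicochemical assay for metabolic stability, read by spectrophotometry, in phosphate buffer, at 25 degrees C, at pH 7.3; a lower number here means that the compound disappears faster, a higher number that the compound lasts longer:
- compound 1 `Cc1ccc(C(=O)n2cc(C#N)c3cccnc32)cc1`: 2.6 h
- compound 2 `CCCCC(=O)n1cc(C#N)c2cccnc21`: 1.9 h

Compound 1 and compound 2 lie within the usual scatter of each other, so the two numbers do not separate them. Compound 3 `CCOC(=O)c1cn(C(=O)c2ccc(C)cc2)c2ncccc12` keeps the core of compound 1 and differs in one group: ethoxycarbonyl in place of cyano on an aromatic carbon. Within the data shown here, no measured pair shows this change, so the expectation is a judgement without direct precedent. A modest lengthening of the half-life is expected in this assay, possibly not beyond the scatter, with an estimated 1.7-fold higher number from compound 1 to compound 3 (0.24 log units; within the scatter). For compound 3 the estimated half-life is 4.5 h, with an expected range from 2.2 h to 10 h.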

Compound 3, half-life: 4.3 h
Beside the measured number, compound 3's estimate is 1.0-fold (0.02 log units) above it; the range from low to high includes it.
By their numbers in this assay, from the lowest: compounds 2, 1 and 3 (each within the scatter of the next, the first and the last beyond it).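

Among these compounds, this is the first measured pair at this aromatic carbon of the shared core: in this assay ethoxycarbonyl in place of cyano gives a 1.7-fold higher number from compound 1 to compound 3 (0.22 log units; within the scatter) and so does not separate the two compounds. Cyano is therefore not needed at this position to keep the half-life within the scatter of compound 1.

Still open, as far as these compounds go, is whether a carboxylic acid, a primary amide or a longer ester on this carbon would stay within that scatter, and whether the same change holds on compound 2. Nothing on hand accounts for the result.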